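Azido for benzylamino on the shared core, pleural-cavity read-out

The source may hold more compounds than are shown below. What is called first, only, known or untested is meant among the compounds shown, and "the series" means these compounds.

Two compounds of this series carry a measurement in a functional assay on the whole organism (Pleural cavity) with Rattus norvegicus as the target; on this read-out lower numbers stand for an effect already at smaller amounts and higher numbers for an effect only at larger amounts of compound. Compound 1 `CSc1nccc2c1ncn2[C@H]1C[C@H](O)[C@@H](CO)O1` is one of them. In this assay compound 1 gives > 9 mg/kg, which is a limit of the assay rather than a number. Compound 2 `OC[C@H]1OC(n2cnc3c(NCc4ccccc4)nccc32)[C@H](O)[C@@H]1O` is the other measured compound. In this assay compound 2 gives > 9 mg/kg, again a limit and not a number. Within the data shown here, compound 2 therefore stands at the limit, and the one further value shown is a limit as well, as the limit of > 9 mg/kg in this assay, at which 2 of the 2 values shown sit, records. Among the measured compounds shown here, no step between measured compounds can be stated from these two limits.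

Compound 3 `[N-]=[N+]=Nc1nccc2c1ncn2C1O[C@H](CO)[C@@H](O)[C@H]1O` is not yet measured. It differs from compound 2 as follows: azido in place of benzylamino on an aromatic carbon. For the measured compounds named here, with no measured step to lean on, no change beyond the usual scatter is expected in this assay, in either direction. For compound 3 the estimate in this assay is 12 mg/kg, ranging from 6 mg/kg to 30 mg/kg. This estimate means a step that the limit leaves unreadable from compound 2 to compound 3 that is expected to stay within the scatter, with a real chance that only a limit is reported again.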

Compound 3, dose for half-maximal effect: > 9 mg/kg
Compound 3 gave a limit, no number (the forecaster's own chance of this, stated with the estimate: 70%); the middle value is on the limit's open side.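

No step from compound 2 to compound 3 can be read in this assay, as both compounds give only a limit of the assay: the limit of > 9 mg/kg in this assay, at which 3 of the 3 values shown sit.

The compounds shown leave open what number any of the three would reach, and whether azido in place of benzylamino changes the read-out at all.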